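Amide substituent change on a dilauroyl lipopeptide scaffold

A few compounds are considered here, and "the series" means these few. Any claim that something is new, unique, unknown or untested is made for them only; others in the source may bear on it.

Compound 1, `CCCCCCCCCCCC(=O)OC[C@H](CSC[C@@H](N)C(=O)NC(C)c1ccccc1)OC(=O)CCCCCCCCCCC`, gives 9900 nM in an assay on HEK293 cells for agonist activity at Toll-like receptor 2 (Homo sapiens) (on this read-out higher numbers stand for an effect only at larger amounts of compound and lower numbers for an effect already at smaller amounts), the highest of the three numbers recorded so far. Compound 2, `CCCCCCCCCCCC(=O)OC[C@H](CSC[C@@H](N)C(=O)N[C@@H](CC)COCC(=O)O)OC(=O)CCCCCCCCCCC`, gives 6500 nM in this assay, and compound 3, `CCCCCCCCCCCC(=O)OC[C@H](CSC[C@@H](N)C(=O)NCCCCN)OC(=O)CCCCCCCCCCC`, gives 1040 nM. The step from compound 1 to compound 2 was a 1.5-fold lower number from compound 1 to compound 2 (0.18 log units; within the scatter), whereas the step to compound 3 was a 9.5-fold lower number from compound 1 to compound 3 (0.98 log units; beyond the scatter), and the step between the other two was a 6.3-fold lower number from compound 2 to compound 3 (0.80 log units; beyond the scatter).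

Compound 4, `CCCCCCCCCCCC(=O)OC[C@H](CSC[C@@H](N)C(=O)NC(C)CCN(CC)CC)OC(=O)CCCCCCCCCCC`, differs from compound 1 in one place: 2-(diethylamino)ethyl in place of phenyl on a saturated chain carbon bound to an amide-type nitrogen and a saturated chain carbon. Among the compounds with values here, the step that bears most directly on this change is the one from compound 1 to compound 3, where an amine-bearing chain replaced the 1-phenylethyl group and the number fell beyond the scatter. The change to compound 4 also brings in a nitrogen-bearing chain, though it keeps the methyl on the carbon bound to the amide-type nitrogen and the nitrogen sits within a longer branched group. The step from compound 1 to compound 2, which introduced a carboxylic acid instead, stayed within the scatter. Compound 4 is therefore expected to show a number lower than that of compound 1, a step of about a 3.3-fold lower number from compound 1 to compound 4 (0.52 log units; beyond the scatter), somewhat smaller than that seen for compound 3. The estimate for compound 4 in this assay is 3000 nM, with a range from 1000 nM to 9000 nM.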

Compound 4, half-maximal effective concentration: 257 nM
The estimate for compound 4 lay 12-fold (1.07 log units) above the measured number, and the stated range ends above it.
By their numbers in this assay, from the lowest: compound 4; then compound 3; then compounds 2 and 1 (each within the scatter of the next).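

Within the data shown here, replacing phenyl with 2-(diethylamino)ethyl on a saturated chain carbon bound to an amide-type nitrogen and a saturated chain carbon gave a 39-fold lower number from compound 1 to compound 4 (1.59 log units; beyond the scatter) in this assay, which shows that this place can carry a step far larger than any seen among the earlier compounds. The step of a 4.0-fold lower number from compound 3 to compound 4 (0.61 log units; beyond the scatter) shows that amine-bearing groups on the amide-type nitrogen do not all read alike, with 3-(diethylamino)-1-methylpropyl ahead of 4-aminobutyl, and the step of a 25-fold lower number from compound 2 to compound 4 (1.40 log units; beyond the scatter) sets it well apart from the carboxylic acid-bearing 1-((carboxymethoxy)methyl)propyl group. No measurement is available that accounts for these steps.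

Since 3-(diethylamino)-1-methylpropyl differs from 4-aminobutyl in both its branching methyl and its two ethyl groups on nitrogen, the compounds shown do not separate the contribution of either feature. Going by these compounds, it remains open how an unbranched 3-(diethylamino)propyl group, a dimethylamino end or a longer chain between the two nitrogens would read on this scaffold.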